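A few compounds are considered here, and "the series" means these few. Any claim that something is new, unique, unknown or untested is made for them only; others in the source may bear on it.

Measured so far in a physicochemical assay for solubility, using the shake flask method, measured as kinetic solubility, with a stated time of 20 h, at pH 2; on this read-out lower numbers stand for lower solubility and higher numbers for higher solubility:
Compound 1 `FC(F)(F)c1cccc(-c2nc3cnc(Nc4ccccn4)cc3[nH]2)c1` gives 21000 nM.
Compound 2 `O=C(O)c1ccnc(Nc2cc3[nH]c(-c4cccc(C(F)(F)F)c4)nc3cn2)c1` gives < 5000 nM, which is a limit of this assay and not a number.

Among the compounds with values here, compound 2 therefore stands at the lower edge of the numbers seen: its value is a limit (the limit of < 5000 nM in this assay, at which 1 of the 2 values shown sits), and the only step measured, an at least 4.2-fold lower number from compound 1 to compound 2 (0.62 log units; beyond the scatter), runs down to that limit. No measured number exists for compound 2 beyond it.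

Compound 3 `FC(F)(F)c1cccc(-c2nc3cnc(Nc4cc(-c5nnn[nH]5)ccn4)cc3[nH]2)c1` differs from compound 2 in one place: 1H-tetrazol-5-yl in place of carboxy on an aromatic carbon. Within the data shown here, the one measured step bears on this change only in part, since an at least 4.2-fold lower number from compound 1 to compound 2 (0.62 log units; beyond the scatter) concerns the carboxy that now leaves, while no measured compound carries the 1H-tetrazol-5-yl that enters. With compound 2 already at a limit, the change from compound 2 to compound 3 is expected to give no step beyond the scatter in this assay, and the chance that compound 3 again returns only a limit is considerable.

Compound 3 is therefore estimated at 4000 nM, with a range from 1000 nM to 15000 nM, which corresponds to an expected step that the limit leaves unreadable from compound 2 to compound 3.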

Compound 3, solubility: < 5000 nM
Compound 3 ended at the assay's limit; the forecaster's own chance of this, stated with the estimate: 55%; the middle value lies beyond the limit too.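

In this assay compound 3 gives < 5000 nM, which is a limit of this assay and not a number. On an aromatic carbon opposite the ring nitrogen, 1H-tetrazol-5-yl in place of hydrogen gives an at least 4.2-fold lower number from compound 1 to compound 3 (0.62 log units; beyond the scatter), so the drop beyond the scatter at this place is no longer seen with carboxy alone: two different groups here now end at the same limit. The step between the two substituted compounds cannot be read with a limit at both ends, so carboxy and 1H-tetrazol-5-yl cannot be ranked against each other, and the limit now holds most of the series: the limit of < 5000 nM in this assay, at which 2 of the 3 values shown sit.

From the compounds shown here alone, whether compound 2 and compound 3 lie just under this limit or far under it remains open, and with that the true size of both steps from compound 1. Also open, going by these compounds, is whether an amine or a primary amide at the same place on the shared core would return a measurable number in this assay rather than a limit.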